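Adding a Methyl to the Phenylsulfonyl Group

The source may hold more compounds than are shown below. What is called first, only, known or untested is meant among the compounds shown, and "the series" means these compounds.

For the measured compounds named here, compound 2 `Nc1nc2c(c(=O)n(CC3CC3)c(=O)n2CC2CC2)n1S(=O)(=O)c1ccccc1` has the lower of the two numbers measured so far: in an assay on isolated protein with dual specificity calcium/calmodulin-dependent 3',5'-cyclic nucleotide phosphodiesterase 1B (Bos taurus) as the target, tested at 100 uM (a higher number here means more inhibition at the concentration tested (going by the name of the read-out), a lower number less inhibition), compound 2 gives 13%. Going by the values given here, compound 1 `Cn1c(N)nc2c1c(=O)n(CC1CC1)c(=O)n2CC1CC1` gives 30% in this assay, and the only step known, a number 17 percentage points lower from compound 1 to compound 2 (beyond the scatter), concerns phenylsulfonyl in place of methyl on an aromatic nitrogen, a different change. Compound 3 `Cc1ccc(S(=O)(=O)n2c(N)nc3c2c(=O)n(CC2CC2)c(=O)n3CC2CC2)cc1` differs from compound 2 by methyl in place of hydrogen on an aromatic carbon. Among the compounds with values here, no measured step bears on this change, so no shift beyond the scatter is expected, no change at the digits printed from compound 2 to compound 3 (within the scatter). Compound 3 is therefore estimated at 13%, within 0% to 30%.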

Compound 3, a percentage reported as inhibition, at one concentration (the size of the read-out at that concentration, not a potency): 9%
Compound 3: the middle estimate sits 4 percentage points above what was measured; the range from low to high includes it.
By their numbers in this assay, from the lowest: compounds 3 and 2 (each within the scatter of the next); then compound 1.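

In this assay, going from phenyl to 4-methylphenyl on the sulfonyl gives a number 4 percentage points lower from compound 2 to compound 3 (within the scatter), so adding this methyl causes no shift that can be read. The (4-methylphenyl)sulfonyl group also keeps the gap from the methyl on the aromatic nitrogen of compound 1, with a number 21 percentage points lower from compound 1 to compound 3 (beyond the scatter), much as phenylsulfonyl did. No evidence is at hand to explain these numbers. On these data alone, whether a chlorine atom, a methoxy group or a carboxylic acid at this ring position would move the number remains open, as does the effect of a methylsulfonyl group on the aromatic nitrogen.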